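Chloro on the benzyl group of compound 3

A few compounds are considered here, and "the series" means these few. Any claim that something is new, unique, unknown or untested is made for them only; others in the source may bear on it.

Measured so far in a physicochemical assay for solubility, with a stated time of 3 days, at pH 7 (on this read-out higher numbers stand for higher solubility and lower numbers for lower solubility), for this series
compound 1 `NC(=O)c1ccc2[nH]c(-c3ccc(OCCCO)cc3)nc2c1` gives 7000 nM as a number
compound 2 `NC(=O)c1ccc2[nH]c(-c3ccc(OCC4CCNCC4)cc3)nc2c1` gives > 400000 nM as a limit, not a number
compound 3 `NC(=O)c1ccc2[nH]c(-c3ccc(OCCC4CCCCN4Cc4ccccc4)cc3)nc2c1` gives 155000 nM as a number

In this assay compound 1 gives 7000 nM and compound 3 gives 155000 nM as the two true numbers, with compound 3 the higher of them.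

Compound 4 `NC(=O)c1ccc2[nH]c(-c3ccc(OCCC4CCCCN4Cc4ccc(Cl)cc4)cc3)nc2c1` differs from compound 3 by chloro in place of hydrogen on an aromatic carbon, which turns benzyl to 4-chlorobenzyl. For the measured compounds named here, the only measured step is an at least 57-fold higher number from compound 1 to compound 2 (1.75 log units; beyond the scatter) and it is large, but it exchanges a different group, so it sets no size for this change. No chloro exchange has been measured in the series.

Starting from compound 3 at 155000 nM a modest step to a lower number is expected, with a wide margin on either side. The estimated step is a 2.2-fold lower number from compound 3 to compound 4 (0.35 log units; beyond the scatter) and rests on this one structural change alone. In this assay compound 4 is estimated at 70000 nM within an expected range of 20000 nM to 220000 nM for this change.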

Compound 4, solubility: 115000 nM
Compound 4: the middle estimate sits 1.6-fold (0.22 log units) below what was measured; low and high end bracket the measured number.
By their numbers in this assay, from the lowest: compound 1; then compounds 4 and 3 (each within the scatter of the next). At a limit, above all of these: compound 2.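

In this assay, the exchange of benzyl for 4-chlorobenzyl gives a step that cannot be told from repeat measurement: a 1.3-fold lower number from compound 3 to compound 4 (0.13 log units; within the scatter). For the compounds shown here, this is the first chloro exchange and the first change on the benzyl group, and it shows that a chloro on this aromatic carbon, para to a large group, leaves compound 3 and compound 4 inseparable on this read-out. Compound 2 stays the only one of the four at a limit, which is not a number, so both members of this pair can be read as true numbers and not against that limit: the limit of > 400000 nM in this assay, at which 1 of the 4 values shown sits.

As far as these compounds go, how an amine or a carboxylic acid in place of the chloro on this ring would read remains open. A single exchange at a single place also sets no size for a larger group, such as phenoxy, at this position.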